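Fluorine on the Benzyl Ring of Compound 2

A few compounds are considered here, and "the series" means these few. Any claim that something is new, unique, unknown or untested is made for them only; others in the source may bear on it.

Measured compounds:
compound 1, `Oc1ccc(C#CCN2CCC(Cc3ccccc3)CC2)cc1`, 1500 nM
compound 2, `Nc1ccc(C#CCCN2CCC(O)(Cc3ccccc3)CC2)cc1`, 63000 nM
compound 3, `Nc1ccc(C#CCCN2CCC(Cc3ccccc3)CC2)cc1`, 1000 nM

In an assay on isolated protein for binding affinity to Adrenergic receptor alpha-1 (Rattus norvegicus), read by radioligand binding (a lower number here means a stronger inhibitor, a higher number a weaker inhibitor), compound 2 stands at the highest of the three numbers. Its nearest neighbour is compound 1, and the step to compound 3 is a 63-fold lower number from compound 2 to compound 3 (1.80 log units; beyond the scatter), a change at a saturated ring carbon.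

Compound 4, `Nc1ccc(C#CCCN2CCC(O)(Cc3ccc(F)cc3)CC2)cc1`, differs from compound 2 by fluoro in place of hydrogen on an aromatic carbon. Among the compounds with values here, the only measured step, a 63-fold lower number from compound 2 to compound 3 (1.80 log units; beyond the scatter), concerns a different position and does not bear on this change; no measured pair shows what a fluoro on the benzyl ring does here. Compound 4 is therefore expected to stay within the scatter of compound 2, a step of no change at the digits printed from compound 2 to compound 4 (within the scatter). The estimate for compound 4 in this assay is 63000 nM, within 25000 nM to 160000 nM.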

Compound 4, half-maximal inhibitory concentration: 31000 nM
Beside the measured number, compound 4's estimate is 2.0-fold (0.31 log units) above it; the measured number falls inside the stated range.
By their numbers in this assay, from the lowest: compounds 3 and 1 (each within the scatter of the next); then compound 4; then compound 2.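

In this assay, fluoro in place of hydrogen on the benzyl ring gives a 2.0-fold lower number from compound 2 to compound 4 (0.31 log units; beyond the scatter), so this position does respond to the change, though only modestly. That step is much smaller than a 63-fold lower number from compound 2 to compound 3 (1.80 log units; beyond the scatter), and compound 4 still carries the hydroxy group. Nothing available explains the shift. As far as these compounds go, whether the same fluoro would move the number on compound 3, which lacks the hydroxy group, remains open. Also open, from the compounds shown here alone, is what a chloro or methoxy group would do in place of the fluoro.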